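The source may hold more compounds than are shown below. What is called first, only, known or untested is meant among the compounds shown, and "the series" means these compounds.

Compound 1 (`CN1CCN(CCCOc2cccc3nc(Nc4ccc(F)c(F)c4)ccc23)CC1`) is one of two analogues measured in a functional assay on cells (Panel ovarian (Carcinoma cell lines), Homo sapiens) for inhibition, read by sulforhodamine B assay, with a stated time of 48 h (a higher number here means a weaker inhibitor of growth, a lower number a stronger inhibitor of growth), where compound 1 gives 10800 nM. Compound 2 (`CN1CCN(CCCOc2cccc3nc(Nc4cc(Cl)cc(Cl)c4)ccc23)CC1`) is the only comparator, and in this assay compound 2 gives 4100 nM. Among the two numbers compound 1 therefore stands highest, and the single measured step, a 2.6-fold lower number from compound 1 to compound 2 (0.42 log units; beyond the scatter), shows that replacing the 3,4-difluorophenyl with a 3,5-dichlorophenyl on the same nitrogen brings a modest gain that clears the scatter.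

Compound 3 (`CN1CCN(CCCOc2cccc3nc(Nc4cccc(Cl)c4)ccc23)CC1`) has not yet been measured. It differs from compound 1 in one place: 3-chlorophenyl in place of 3,4-difluorophenyl on a nitrogen on an aromatic ring. This is a related but not identical change to the measured step, since only one chlorine enters rather than two. For the measured compounds named here, the only evidence that bears on it is the step from compound 1 to compound 2, and that step was modest. A move in the same direction, of similar or somewhat smaller size, is expected in this assay for compound 3, and it could fall within the scatter.

Compound 3 is expected to give about 6500 nM in this assay, plausibly between 2500 nM and 17000 nM. That estimate corresponds to a 1.7-fold lower number from compound 1 to compound 3 (0.22 log units; within the scatter), an expected step in the same direction as the measured one.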

Compound 3, concentration for total growth inhibition: 4310 nM
Estimate against measurement, compound 3: 1.5-fold (0.18 log units) above, within the range that was stated.
By their numbers in this assay, from the lowest: compounds 2 and 3 (each within the scatter of the next); then compound 1.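

In this assay, the 3-chlorophenyl group on the nitrogen already gives the full gain seen so far over the 3,4-difluorophenyl group, with a 2.5-fold lower number from compound 1 to compound 3 (0.40 log units; beyond the scatter). Going on to the 3,5-dichlorophenyl group adds nothing that can be read, since putting hydrogen in place of chloro on an aromatic carbon gives a 1.1-fold higher number from compound 2 to compound 3 (0.02 log units; within the scatter), so among these compounds the additional chloro of compound 2 is not needed for the gain over compound 1. No measurement available here explains why these aryl groups differ or why the additional chloro makes no readable difference.

The step from compound 1 to compound 3 exchanges the fluoro groups for chloro and alters the substitution pattern in one move, so the compounds shown cannot say whether the gain comes from the chloro entering or the fluoro groups leaving. An unsubstituted phenyl, a 3-fluorophenyl or a 3-bromophenyl group on the same nitrogen would separate these readings, and a 3-methoxyphenyl group would show whether a halogen is needed there at all.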